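The compounds below may be only part of what the source reports. "The series", "measured", "known", "first", "only" and "open" are said of these compounds alone.

Of the compounds shown here, three have been measured in a functional assay on HCC827 cells (Homo sapiens) for inhibition, read by MTT assay, with a stated time of 48 h, tested at 10 uM; on this read-out lower numbers stand for less inhibition and higher numbers for more inhibition at the one concentration tested (going by the name of the read-out). Compound 1 `COc1ccc(F)cc1Nc1cc(NC(=O)Nc2c(Cl)cccc2Cl)ncn1` gives 78%, compound 2 `COc1cc(NC(=O)Nc2cc(Nc3ccc(C)c(C)c3)ncn2)cc(OC)c1` gives 45.7%, and compound 3 `COc1cc(NC(=O)Nc2cc(Nc3cc(F)ccc3OC)ncn2)cc(OC)c1` gives 59%. Compound 3 thus stands second highest of the three: the step of a number 19 percentage points lower from compound 1 to compound 3 (beyond the scatter) lies beyond the scatter, and so does the step of a number 13.3 percentage points higher from compound 2 to compound 3 (beyond the scatter).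

Compound 4 `COc1cc(NC(=O)Nc2cc(Nc3cc(C)cc(F)c3)ncn2)cc(OC)c1` differs from compound 3 at one place: 3-fluoro-5-methylphenyl in place of 5-fluoro-2-methoxyphenyl on a nitrogen on an aromatic ring. For the measured compounds named here, the 5-fluoro-2-methoxyphenyl that leaves is the very group whose arrival in place of 3,4-dimethylphenyl brought the step of a number 13.3 percentage points higher from compound 2 to compound 3 (beyond the scatter), so this is the one measured step that bears directly on the change. The entering 3-fluoro-5-methylphenyl carries a fluorine, like the group that leaves, but also a methyl, like the 3,4-dimethylphenyl of compound 2, and it has no hydrogen-bond acceptor. Part of that earlier gain is therefore expected to be given back, an expected step of a number 8 percentage points lower from compound 3 to compound 4 (within the scatter) in this assay, a modest drop. Compound 4 is estimated at 51%, within a range from 38% to 64%.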

Compound 4, a percentage reported as inhibition, at one concentration (the size of the read-out at that concentration, not a potency): 62.1%
Compound 4: the middle estimate sits 11.1 percentage points below what was measured; low and high end bracket the measured number.
By their numbers in this assay, from the lowest: compound 2; then compounds 3 and 4 (each within the scatter of the next); then compound 1.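

In this assay, 3-fluoro-5-methylphenyl in place of 5-fluoro-2-methoxyphenyl gives a number 3.1 percentage points higher from compound 3 to compound 4 (within the scatter), so at this position a group with no hydrogen-bond acceptor reads level with one that has a methoxy group. Set against 3,4-dimethylphenyl, the same group gives a number 16.4 percentage points higher from compound 2 to compound 4 (beyond the scatter), which shows that a methyl on this ring does not by itself keep the number low, and among compound 2, compound 3 and compound 4 the two fluorine-bearing groups both stand above the group without fluorine. Nothing shown here offers a measured reason for these readings.

From the compounds shown here alone, whether the fluorine itself accounts for the difference from 3,4-dimethylphenyl stays open, as does how a ring carrying a morpholine or a carboxylic acid would read at this nitrogen. Also open, going by these compounds, is whether 3-fluoro-5-methylphenyl would keep its standing with the 2,6-dichlorophenyl of compound 1 on the amide-type nitrogen.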